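Swapping the Ketone Aryl Ring: Methoxyphenyl to Difluorophenyl

The source may hold more compounds than are shown below. What is called first, only, known or untested is meant among the compounds shown, and "the series" means these compounds.

Measured compounds:
compound 1 `COc1cc(-c2cc(/C=C/C(=O)c3ccc(N)cc3)[nH]n2)cc(OC)c1OC` gives 66%
compound 2 `COc1ccc(-c2cc(/C=C/C(=O)c3ccc(N)cc3)[nH]n2)cc1` gives 42%
compound 3 `COc1ccc(C(=O)/C=C/c2cc(-c3cc(OC)c(OC)c(OC)c3)n[nH]2)cc1` gives 57%

In a functional assay on MCF7 cells (Homo sapiens) for cytotoxicity, read by sulforhodamine B assay, with a stated time of 48 h, tested at 1 uM (a lower number here means a stronger effect, a higher number a weaker effect of the compound at the concentration tested), compound 3 stands second highest of the three numbers: compound 1 sits higher by a margin within the scatter, and compound 2 sits lower by a margin beyond it. Compound 4 `COc1cc(-c2cc(/C=C/C(=O)c3ccc(F)c(F)c3)[nH]n2)cc(OC)c1OC` has not yet been measured. It differs from compound 3 by 3,4-difluorophenyl in place of 4-methoxyphenyl on a carbonyl carbon. Within the data shown here, the only measured step at that ring, a number 9 percentage points lower from compound 1 to compound 3 (within the scatter), was small. Nothing measured here involves a difluorophenyl, so the expected step of a number 2 percentage points lower from compound 3 to compound 4 (within the scatter) is taken as modest, with no clear direction beyond the scatter. Compound 4 is therefore estimated at 55%, within a range from 35% to 75%.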

Compound 4, a percentage reported as activity, at one concentration (the size of the read-out at that concentration, not a potency): 99%
Compound 4: middle estimate off by 44 percentage points, on the low side, and the stated range ends below it.
By their numbers in this assay, from the lowest: compound 2; then compounds 3 and 1 (each within the scatter of the next); then compound 4.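

In this assay the group on the carbonyl carbon proves able to decide the outcome: the number is a number 42 percentage points higher from compound 3 to compound 4 (beyond the scatter) with 3,4-difluorophenyl in place of 4-methoxyphenyl, and a number 33 percentage points higher from compound 1 to compound 4 (beyond the scatter) with it in place of 4-aminophenyl. The earlier swap between 4-aminophenyl and 4-methoxyphenyl stayed within the scatter, so the position is not indifferent to every aryl group. Nothing available explains this loss of effect.

As far as these compounds go, whether 4-fluorophenyl or 4-hydroxyphenyl would behave like the difluorophenyl remains open. So does whether 3,4-difluorophenyl would cost as much on the core of compound 2.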